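The compounds below may be only part of what the source reports. "The series", "measured", "known", "first", "only" and "open" are said of these compounds alone.

Measured compounds:
- Compound 1 `C=C(F)C(=O)Nc1cc(Nc2nccc(-c3cn(C)c4ccccc34)n2)c(OC)cc1N(C)CCN(C)C`: in a functional assay on HepG2 cells (Homo sapiens) for antiproliferative activity, read by MTT assay, with a stated time of 72 h (on this read-out lower numbers stand for stronger inhibition and higher numbers for weaker inhibition), compound 1 gives 3790 nM
- Compound 2 `C=C(Cl)C(=O)Nc1cc(Nc2nccc(-c3cn(C)c4ccccc34)n2)c(OC)cc1N(C)CCN(C)C`: in this assay compound 2 gives 1390 nM

Among the measured compounds shown here, of the two numbers, compound 2 holds the lower one; the only neighbouring point is compound 1, and the step of a 2.7-fold lower number from compound 1 to compound 2 (0.44 log units; beyond the scatter) is modest. Compound 3 `COc1cc(N(C)CCN(C)C)c(NC(=O)C(Cl)=C(Cl)Cl)cc1Nc1nccc(-c2cn(C)c3ccccc23)n1` differs from compound 2 by 1,2,2-trichloroethenyl in place of 1-chloroethenyl on a carbonyl carbon. For the measured compounds named here, no measured step covers further chlorine on the chain; the one that bears at all, a 2.7-fold lower number from compound 1 to compound 2 (0.44 log units; beyond the scatter), concerns a single chloro in place of fluoro. With so little to rest on, compound 3 is expected to give 4500 nM in this assay, within 1200 nM to 18000 nM. That estimate means a step of a 3.2-fold higher number from compound 2 to compound 3 (0.51 log units; beyond the scatter), expected to land slightly beyond the scatter toward a higher number.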

Compound 3, half-maximal inhibitory concentration: > 50000 nM
Compound 3 gave a limit, no number (the forecaster's own chance of this, stated with the estimate: 10%); middle value at least 11-fold (1.04 log units) from the limit.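

In this assay compound 3 gives only a limit, not a number: > 50000 nM. Even so, the group on the carbonyl carbon proves far more sensitive than the single halogen exchange suggested: 1,2,2-trichloroethenyl gives an at least 35-fold higher number from compound 2 to compound 3 (1.55 log units; beyond the scatter) and an at least 13-fold higher number from compound 1 to compound 3 (1.12 log units; beyond the scatter). The gain seen with one chloro in compound 2 therefore does not carry over to the more heavily chlorinated chain of compound 3.

On these data alone, how far the true value of compound 3 lies past its limit remains open. So does whether a plain ethenyl or a 1-bromoethenyl group on the carbonyl carbon would sit nearer compound 2 or compound 3.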